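A New Amide Estimated for Phosphodiesterase Inhibition

The compounds below may be only part of what the source reports. "The series", "measured", "known", "first", "only" and "open" are said of these compounds alone.

Within the data shown here, compound 2 `COc1ccc(C(=O)Nc2c(C)cccc2Cl)cc1OC1CCCC1` is one of two compounds measured in an assay on isolated protein for inhibition of phosphodiesterase 4A (Sus scrofa); a higher number here means a weaker inhibitor, a lower number a stronger inhibitor. In this assay compound 2 gives 100 nM, the lowest of the two numbers, while compound 1 `COc1ccc(C(=O)Nc2ccccc2Cl)cc1OC1CCCC1` gives 190 nM. Among the measured compounds shown here, the only step between them, a 1.9-fold lower number from compound 1 to compound 2 (0.28 log units; within the scatter), lies within the scatter, so the two values show no difference that can be trusted.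

Compound 3 `COc1ccc(C(=O)Nc2ccccc2SC)cc1OC1CCCC1` has not yet been measured in this assay. It differs from compound 2 by 2-(methylsulfanyl)phenyl in place of 2-chloro-6-methylphenyl on an amide-type nitrogen. For the measured compounds named here, no measured step matches this change: the single step from compound 1 to compound 2 concerned a methyl group only and stayed within the scatter, and nothing measured shows what the exchange of chlorine for a methylsulfanyl group does at this place. The step of a 2.0-fold higher number from compound 2 to compound 3 (0.30 log units; within the scatter) is therefore expected to be small, not clearly beyond the scatter in either direction. Compound 3 is estimated at 200 nM in this assay, with a range from 60 nM to 700 nM that allows for the unknown effect of the new group.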

Compound 3, half-maximal inhibitory concentration: 1200 nM
Estimate against measurement, compound 3: 6.0-fold (0.78 log units) below; the measured number lies above the stated range.
By their numbers in this assay, from the lowest: compounds 2 and 1 (each within the scatter of the next); then compound 3.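

In this assay, among these compounds, the change on the amide-type nitrogen, 2-(methylsulfanyl)phenyl in place of 2-chloro-6-methylphenyl, is the first in this small set to move the number clearly beyond the scatter (a 12-fold higher number from compound 2 to compound 3 (1.08 log units; beyond the scatter)). The simpler comparison, methylsulfanyl in place of chloro on an aromatic carbon with no other difference, also goes beyond the scatter (a 6.3-fold higher number from compound 1 to compound 3 (0.80 log units; beyond the scatter)), so this exchange alone is enough to give a weaker inhibitor, whereas the methyl step stayed within the scatter (a 1.9-fold lower number from compound 1 to compound 2 (0.28 log units; within the scatter)). What lies behind the higher number of compound 3 cannot be said, as no supporting measurement bears on it.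

The compounds shown leave open whether the loss follows methylsulfanyl in particular or would also appear with other groups in place of chloro, such as methoxy, bromo or a longer chain like ethylsulfanyl. They also leave open whether a methyl group added to the ring of compound 3, in the place it holds in compound 2, would change the number at all.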